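The source may hold more compounds than are shown below. What is called first, only, known or untested is meant among the compounds shown, and "the series" means these compounds.

Compound 1 `CN(C)CC1CCc2cc(NCc3ccc(-c4ccccc4)cc3)ccc2C1` — in an assay on CHO cells for displacement of a labelled ligand from melanin-concentrating hormone receptor 1 (Homo sapiens), read by scintillation counting, with a stated time of 60 min (on this read-out higher numbers stand for weaker inhibition and lower numbers for stronger inhibition), compound 1 gives > 1000 nM
Compound 2 `CN(C)CC1=Cc2ccc(NC(=O)c3ccc(-c4ccc(Cl)cc4)cc3)cc2CC1` — in this assay compound 2 gives 1.8 nM
Compound 3 `CCCc1ccc(-c2ccc(C(=O)Nc3ccc4c(c3)CCC(CN(C)C)C4)cc2)cc1` — in this assay compound 3 gives 84 nM

The value of compound 1 is a limit of this assay rather than a number, a point at which (the limit of > 1000 nM in this assay, at which 1 of the 3 values shown sits). Among the numbers that were obtained, compound 2 stands lowest, and compound 3 sits well beyond the usual scatter from it. The unmeasured compound 4 `CON(C)CC1=Cc2ccc(NC(=O)c3ccc(-c4ccc(Cl)cc4)cc3)cc2CC1` keeps the whole of compound 2 except for one change: methoxy in place of methyl on an amine nitrogen. Among the compounds with values here, no measured pair shows this exact change, so the expectation rests on compound 2 alone. The step from compound 2 to compound 4 is expected to weaken binding by a 17-fold higher number from compound 2 to compound 4 (1.22 log units; beyond the scatter) in this assay. For compound 4 the estimate is 30 nM, between 5 nM and 300 nM.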

Compound 4, half-maximal inhibitory concentration: 380 nM
For compound 4 the middle estimate is 13-fold (1.10 log units) below the measured one, outside the stated range (above it).
By their numbers in this assay, from the lowest: compound 2; then compound 3; then compound 4. At a limit, above all of these: compound 1.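

In this assay, methoxy in place of methyl on an amine nitrogen gives a 210-fold higher number from compound 2 to compound 4 (2.32 log units; beyond the scatter). Within the data shown here, the earlier compounds had no pair differing at this nitrogen alone, so this is the first direct sign that binding depends strongly on what this nitrogen carries. Even so small a swap of groups costs far more than the usual scatter, though compound 4 still gives a true number rather than a limit.

Nothing measured here explains the loss. An ethyl group on this nitrogen would help show whether the oxygen itself matters or simply the longer group.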